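This account rests on a few compounds, and the source may have more. Where it says the series, first, only, none or still open, it means among the compounds named here.

Of the compounds shown here, three sharing one core have been tested in an ADME assay on HEK293 cells (Homo sapiens) for cytotoxicity, read by MTT assay, with a stated time of 48 h; on this read-out higher numbers stand for weaker inhibition and lower numbers for stronger inhibition. Compound 1 `Cn1c(N)c(-c2nc3ccccc3[nH]2)c2nc(C#N)c(C#N)nc21` gives > 50000 nM, which is a limit and not a number. Compound 3 `N#Cc1nc2c(-c3nc4ccccc4[nH]3)c(N)n(CCO)c2nc1C#N` gives > 50000 nM, which is also only a limit. Compound 2 `CCN(CC)CCn1c(N)c(-c2nc3ccccc3[nH]2)c2nc(C#N)c(C#N)nc21` alone gives a true number, 12200 nM.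

Compound 4 `CN(C)CCCn1c(N)c(-c2nc3ccccc3[nH]2)c2nc(C#N)c(C#N)nc21` differs from compound 3 by (dimethylamino)methyl in place of hydroxy on a saturated chain carbon, two bonds along the chain from an aromatic nitrogen: (dimethylamino)methyl in place of hydroxy, on a saturated chain carbon, two bonds along the chain from an aromatic nitrogen. Put another way, 2-hydroxyethyl becomes 3-(dimethylamino)propyl.

Within the data shown here, two measured steps bear on this change. Adding (diethylamino)methyl gave an at least 4.0-fold lower number from compound 1 to compound 2 (0.61 log units; beyond the scatter), and hydroxy in place of diethylamino gave an at least 4.0-fold higher number from compound 2 to compound 3 (0.61 log units; beyond the scatter). Both lie beyond the scatter, and both link the amino-bearing chain to the lower number. Compound 4 carries dimethylamino on a longer chain, so compound 2 is only a rough guide. A step toward lower numbers is still expected, estimated as an at least 3.3-fold lower number from compound 3 to compound 4 (0.52 log units; beyond the scatter). For compound 4 the estimated value is 15000 nM, with an expected range from 6000 nM to 40000 nM.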

Compound 4, half-maximal inhibitory concentration: 8360 nM
Estimate against measurement, compound 4: 1.8-fold (0.25 log units) above; the measured number falls inside the stated range.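

In this assay, a second amine-bearing chain now gives a true number: 2-hydroxyethyl becoming 3-(dimethylamino)propyl brings an at least 5.9-fold lower number from compound 3 to compound 4 (0.77 log units; beyond the scatter), and the same chain set against the smaller methyl group brings an at least 5.9-fold lower number from compound 1 to compound 4 (0.77 log units; beyond the scatter). With (dimethylamino)methyl in place of diethylamino, the result is a 1.5-fold lower number from compound 2 to compound 4 (0.16 log units; within the scatter), so the two amine chains cannot be told apart here, even though the groups on the nitrogen and the chain length both differ. The two larger steps start from a limit, not a number, and so give only a minimum size: the limit of > 50000 nM in this assay, at which 2 of the 4 values shown sit.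

A 3-(diethylamino)propyl chain would help to separate chain length from the groups on the amine. On these data alone, whether a chain ending in a primary amine or a carboxylic acid would give a lower number remains open.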